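Pyridin-4-yl in place of 4-methoxyphenyl on the shared core

The source may hold more compounds than are shown below. What is called first, only, known or untested is meant among the compounds shown, and "the series" means these compounds.

Measured in a functional assay on HT-29 cells (Homo sapiens) for inhibition, with a stated time of 72 h; on this read-out higher numbers stand for weaker inhibition and lower numbers for stronger inhibition:
Compound 1 `COc1ccc(S(=O)(=O)N2CCc3cccc(-c4ccco4)c32)cc1`: 62.5 nM
Compound 2 `COc1ccc(S(=O)(=O)N2CCc3cccc(-c4ccc(N(C)C)cc4)c32)cc1`: 467 nM
Compound 3 `COc1ccc(-c2cccc3c2N(S(=O)(=O)c2ccc(OC)cc2)CC3)cc1`: 277 nM

The standing of compound 3 in this assay rests on two steps. There is a 1.7-fold lower number from compound 2 to compound 3 (0.23 log units; within the scatter), and there is a 4.4-fold higher number from compound 1 to compound 3 (0.65 log units; beyond the scatter). Compound 4 `COc1ccc(S(=O)(=O)N2CCc3cccc(-c4ccncc4)c32)cc1` carries pyridin-4-yl in place of 4-methoxyphenyl on an aromatic carbon, (pyridin-4-yl in place of 4-methoxyphenyl on an aromatic carbon).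

Among the compounds with values here, no measured step makes this exact change, but the steps at the same place bear on it. These are a 7.5-fold higher number from compound 1 to compound 2 (0.87 log units; beyond the scatter) and a 4.4-fold higher number from compound 1 to compound 3 (0.65 log units; beyond the scatter), both modest. Pyridin-4-yl has a six-membered aromatic ring, like the groups of compound 2 and compound 3, yet it also has a hetero atom in its ring, as the furan-2-yl of compound 1 does. A small move towards the lower number of compound 1 is therefore expected, possibly not beyond the scatter. The expected change is a 1.8-fold lower number from compound 3 to compound 4 (0.27 log units; within the scatter). The estimate for compound 4 is 150 nM, with an expected range of 45 nM to 500 nM.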

Compound 4, half-maximal inhibitory concentration: 87.5 nM
For compound 4 the middle estimate is 1.7-fold (0.23 log units) above the measured one, within the range that was stated.
By their numbers in this assay, from the lowest: compounds 1 and 4 (each within the scatter of the next); then compounds 3 and 2 (each within the scatter of the next).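

In this assay, pyridin-4-yl gives a 3.2-fold lower number from compound 3 to compound 4 (0.50 log units; beyond the scatter) and a 5.3-fold lower number from compound 2 to compound 4 (0.73 log units; beyond the scatter), so a six-membered aromatic ring at this position does not by itself bring the higher numbers of compound 2 and compound 3. With a 1.4-fold higher number from compound 1 to compound 4 (0.15 log units; within the scatter), pyridin-4-yl and furan-2-yl stand level, and among these four compounds the two groups with a hetero atom in the ring give the lower numbers, whatever the ring size. Nothing in the data gives a reason for this difference.

Still open, as far as these compounds go, is how plain phenyl would compare, which would separate the effect of the hetero atom in the ring from that of losing the substituent on the ring. Also open, from the compounds shown here alone, is whether pyridin-3-yl, pyridin-2-yl or thiophen-2-yl would stay at the level of compound 1 and compound 4.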